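This account rests on a few compounds, and the source may have more. Where it says the series, first, only, none or still open, it means among the compounds named here.

Working notes on the ester series. Compound 1 `COc1nc(C)c(Nc2nc(Cl)cn([C@H](COC(C)=O)C3CC3)c2=O)cc1C` carries an acetoxy group on the side chain; in an assay on frontal cortex for displacement of a labelled ligand from corticotropin-releasing factor receptor 1 (Rattus norvegicus), with a stated time of 2 h (on this read-out lower numbers stand for stronger inhibition and higher numbers for weaker inhibition), compound 1 gives 5.3 nM. Compound 2 `COc1nc(C)c(Nc2nc(Cl)cn([C@H](COC(=O)c3ccccc3)C3CC3)c2=O)cc1C` gives 1.5 nM and compound 3 `COc1nc(C)c(Nc2nc(Cl)cn([C@H](COC(=O)c3cccnc3)C3CC3)c2=O)cc1C` gives 5.2 nM. Compound 1 therefore stands at the highest of the three numbers: its step to compound 3 stays within the scatter, while a 3.5-fold lower number from compound 1 to compound 2 (0.55 log units; beyond the scatter) is a modest step beyond the scatter, and a 3.5-fold higher number from compound 2 to compound 3 (0.54 log units; beyond the scatter) returns that gain.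

Compound 4 `COc1nc(C)c(Nc2nc(Cl)cn([C@H](COC(=O)Nc3ccccc3Cl)C3CC3)c2=O)cc1C` is not yet measured. Relative to compound 1 the difference is (2-chlorophenyl)amino in place of methyl on a carbonyl carbon. The two measured steps that replace the same methyl with a six-membered aromatic ring on the carbonyl carbon bear on it: one modest lowering of the number, one no change. Among the measured compounds shown here, the entering group here is a (2-chlorophenyl)amino group rather than a directly attached ring, so neither step is a direct match, and no step with a carbamate is available.

For compound 4 a modest lowering of the number is expected, estimated as a 2.1-fold lower number from compound 1 to compound 4 (0.33 log units; beyond the scatter), giving an expected value of 2.5 nM with a range from 0.8 nM to 8 nM.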

Compound 4, half-maximal inhibitory concentration: 1.5 nM
Estimate against measurement, compound 4: 1.7-fold (0.22 log units) above, within the range that was stated.
By their numbers in this assay, from the lowest: compounds 2 and 4 (each within the scatter of the next); then compounds 3 and 1 (each within the scatter of the next).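

On this carbonyl carbon, (2-chlorophenyl)amino in place of phenyl gives no change at the digits printed from compound 2 to compound 4 (within the scatter) and so the carbamate, with its ring and hydrogen-bond donor, holds the level of the phenyl ester in this assay as a second group at that level. Against the other two esters, the change gives a 3.5-fold lower number from compound 1 to compound 4 (0.55 log units; beyond the scatter) and a 3.5-fold lower number from compound 3 to compound 4 (0.54 log units; beyond the scatter) and these steps match in size those already seen for phenyl in place of methyl and of pyridin-3-yl. Nothing available bears on the cause of these steps.

Open, on these data alone, is how much of this level rests on the chlorine and how much on the amino nitrogen, a question a plain phenylamino group would address. Also open, as far as these compounds go, is whether a free hydroxyl in place of the whole acetoxy group would keep any of it.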